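A few compounds are considered here, and "the series" means these few. Any claim that something is new, unique, unknown or untested is made for them only; others in the source may bear on it.

Three compounds have been measured in a functional assay on B16-F10 cells (Mus musculus) for cytotoxicity; on this read-out higher numbers stand for weaker inhibition and lower numbers for stronger inhibition:

Compound 1 `O=c1oc2ccccc2c2nc3c(ccc4cc[nH]c43)c(-c3ccccn3)c12` gives 70700 nM.
Compound 2 `O=c1oc2ccccc2c2nc3c(ccc4cc[nH]c43)c(-c3ccc([N+](=O)[O-])cc3)c12` gives 70700 nM.
Compound 3 `O=c1cc(O)c2cc(Cl)ccc2o1` gives 70700 nM.

Compound 1 stands level with compounds 2 and 3 on these numbers, within the scatter of both. Among the measured compounds shown here, the one step that bears on the change in hand is the one at the same aromatic carbon of the shared core, no change at the digits printed from compound 1 to compound 2 (within the scatter), which left the read-out unchanged. Compound 4 `O=c1oc2ccccc2c2nc3c(ccc4cc[nH]c43)c(-c3cccc(Cl)c3Cl)c12` differs from compound 1 as follows: 2,3-dichlorophenyl in place of pyridin-2-yl on an aromatic carbon. For the measured compounds named here, since the only comparable step did not move the read-out, compound 4 is expected to show no step beyond the scatter, no change at the digits printed from compound 1 to compound 4 (within the scatter). The estimate for compound 4 in this assay is therefore 70700 nM, expected to fall between 35000 nM and 100000 nM.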

Compound 4, half-maximal inhibitory concentration: 70700 nM
Compound 4: the middle estimate sits on the measured number at the digits printed; measured number inside the range.
By their numbers in this assay, from the lowest: compounds 1, 2, 3 and 4 (each within the scatter of the next).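

At the aromatic carbon opposite the ring nitrogen, 2,3-dichlorophenyl in place of pyridin-2-yl gives no change at the digits printed from compound 1 to compound 4 (within the scatter) in this assay and, in place of 4-nitrophenyl, no change at the digits printed from compound 2 to compound 4 (within the scatter) at the same carbon. A ring of carbon only bearing two chlorines, with no hydrogen-bond acceptor, thus reads the same here as the pyridin-2-yl ring, which has one. Nothing at hand offers a reason for this flat read-out.

The compounds shown leave open whether a group other than an aromatic ring at this carbon, such as an amine or a carboxylic acid, would move the read-out.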